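The source may hold more compounds than are shown below. What is called first, only, known or untested is meant among the compounds shown, and "the series" means these compounds.

Three compounds share one core and have been measured in a functional assay on HPAC cells (Homo sapiens) for inhibition, read by MTT assay, with a stated time of 72 h; a higher number here means a weaker inhibitor of growth, a lower number a stronger inhibitor of growth:

Compound 1 `O=S(=O)(NCCCNCc1ccccc1Cl)c1cc(C(F)(F)F)cc(C(F)(F)F)c1` gives 10000 nM.
Compound 2 `CC(C)(C)c1ccc(CNCCCNS(=O)(=O)c2cc(C(F)(F)F)cc(C(F)(F)F)c2)cc1` gives 2300 nM.
Compound 3 `COc1ccc(CNCCCNS(=O)(=O)c2cc(C(F)(F)F)cc(C(F)(F)F)c2)cc1` gives 3000 nM.

Compound 3 stands second highest of the three numbers in this assay. Its nearest neighbour is compound 2, with a 1.3-fold higher number from compound 2 to compound 3 (0.12 log units; within the scatter), a gap within the scatter, so the two cannot be told apart. The furthest is compound 1, with a 3.3-fold lower number from compound 1 to compound 3 (0.52 log units; beyond the scatter), a gap beyond the scatter.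

Compound 4 `O=S(=O)(NCCCNCc1cccc(Cl)c1)c1cc(C(F)(F)F)cc(C(F)(F)F)c1` is the next compound, not yet measured. It differs from compound 3 in one place: 3-chlorophenyl in place of 4-methoxyphenyl on a saturated chain carbon bound to an amine nitrogen.

Within the data shown here, no measured step replaces a 4-methoxyphenyl with a 3-chlorophenyl, so the expectation rests on neighbouring steps. The 2-chlorophenyl of compound 1 gave the highest number of the three, and replacing it with either 4-(tert-butyl)phenyl or 4-methoxyphenyl lowered the number by a modest amount, shown by a 4.3-fold lower number from compound 1 to compound 2 (0.64 log units; beyond the scatter) and a 3.3-fold lower number from compound 1 to compound 3 (0.52 log units; beyond the scatter). A 3-chlorophenyl has not been tried, and the measured steps do not say whether it behaves like the 2-chlorophenyl of compound 1 or like the two groups of compounds 2 and 3. The estimate therefore sits between those two outcomes. For compound 4 the expected step is a 1.7-fold higher number from compound 3 to compound 4 (0.22 log units; within the scatter). Compound 4 is expected to give about 5000 nM, with a range from 2000 nM to 15000 nM.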

Compound 4, concentration for 50% growth inhibition: 2700 nM
The estimate for compound 4 lay 1.9-fold (0.27 log units) above the measured number; the range from low to high includes it.
By their numbers in this assay, from the lowest: compounds 2, 4 and 3 (each within the scatter of the next); then compound 1.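

In this assay, replacing the 2-chlorophenyl with a 3-chlorophenyl on the saturated chain carbon bound to an amine nitrogen gives a 3.7-fold lower number from compound 1 to compound 4 (0.57 log units; beyond the scatter), so the high number of compound 1 does not extend to every chlorophenyl group at this place. The other two steps, a 1.1-fold lower number from compound 3 to compound 4 (0.05 log units; within the scatter) and a 1.2-fold higher number from compound 2 to compound 4 (0.07 log units; within the scatter), are both within the scatter, so the 3-chlorophenyl, 4-methoxyphenyl and 4-(tert-butyl)phenyl groups cannot be told apart here, even though the 4-methoxyphenyl has a hydrogen-bond acceptor that the 3-chlorophenyl lacks. Nothing available explains why the 2-chlorophenyl stands apart from these three groups.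

The compounds shown leave open how a plain phenyl, a 4-chlorophenyl or a pyridine ring would behave at this place, and so whether the 2-chlorophenyl of compound 1 is a lone exception. They also leave open whether any group here, or a longer chain in the shared core, could give a number well short of that of compound 2, which stands at 2300 nM.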